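This account rests on a few compounds, and the source may have more. Where it says the series, first, only, none or still open, it means among the compounds named here.

Measured compounds:
compound 1 `COc1ccccc1-n1cc(COc2c(/C=C\C(=O)O)ccc(OC)c2CC=C(C)C)nn1` — 41500 nM
compound 2 `COc1ccc(-n2cc(COc3c(/C=C\C(=O)O)ccc(OC)c3CC=C(C)C)nn2)cc1` — "not determined" (no result reported)

In a functional assay on NCI-H322 cells (Homo sapiens) for cytotoxicity, read by MTT assay, with a stated time of 24 h (on this read-out lower numbers stand for stronger inhibition and higher numbers for weaker inhibition), compound 1 gives 41500 nM. Compound 2 has no single number in this assay; it gives "not determined" (no result reported), so its standing cannot be placed on the scale. The change from compound 2 to compound 3 `COc1ccc(/C=C\C(=O)O)c(OCc2cn(-c3ccc(C#N)cc3)nn2)c1CC=C(C)C` is cyano in place of methoxy on an aromatic carbon. Going by the values given here, with no measured step of this kind and no number for compound 2, the size and direction of the step in this assay cannot be read from the data. Compound 3 is expected to come in near 40000 nM, with a range from 10000 nM to 150000 nM, estimated from the weak value of compound 1 41500 nM as the only reference.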

Compound 3, half-maximal inhibitory concentration: 18600 nM
Beside the measured number, compound 3's estimate is 2.2-fold (0.33 log units) above it; measured number inside the range.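

In this assay, replacing 2-methoxyphenyl with 4-cyanophenyl on an aromatic nitrogen gives a 2.2-fold lower number from compound 1 to compound 3 (0.35 log units; beyond the scatter), so this position tolerates a change of aryl group with a modest shift beyond the scatter. This step alters both the group and where it sits on the phenyl ring, and the step from compound 2 to compound 3 cannot be read, so the two changes stay unseparated. No evidence is available to explain the shift. On these data alone, it remains open how an amine or a chlorine in place of the cyano group would read.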